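From Methoxy to Nitro: Expecting the Value of Compound 3

This account rests on a few compounds, and the source may have more. Where it says the series, first, only, none or still open, it means among the compounds named here.

Among the measured compounds shown here, compound 1 `COc1ccc(NC(=S)NCCNS(=O)(=O)c2sccc2-c2ccc(C)cc2Oc2ccc(O)c(O)c2)cc1` is the only compound here with a numeric result: in a functional assay on RS4-11 cells (Homo sapiens) for inhibition, read by CCK-8 assay, with a stated time of 48 h (on this read-out lower numbers stand for stronger inhibition and higher numbers for weaker inhibition), compound 1 gives 8300 nM. Compound 2 `COc1ccc(Oc2ccc([N+](=O)[O-])cc2-c2ccsc2S(=O)(=O)N2CCN(C(=O)Nc3ccc([N+](=O)[O-])cc3)CC2)cc1OC` reaches only a limit of this assay, giving > 50000 nM. The untested compound 3 `Cc1ccc(-c2ccsc2S(=O)(=O)NCCNC(=S)Nc2ccc([N+](=O)[O-])cc2)c(Oc2ccc(O)c(O)c2)c1` differs from compound 1 by a single change (nitro in place of methoxy on an aromatic carbon). For the measured compounds named here, no step between two measured compounds is available, so the direction of this change remains open; the expected step from compound 1 to compound 3 is a 1.0-fold lower number from compound 1 to compound 3 (0.02 log units; within the scatter), essentially none beyond the usual scatter. Compound 3 is therefore estimated to give 8000 nM, lying between 3000 nM and 25000 nM.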

Compound 3, half-maximal inhibitory concentration: 5100 nM
The estimate for compound 3 lay 1.6-fold (0.20 log units) above the measured number; the measured number falls inside the stated range.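

In this assay, among the compounds shown here, nitro in place of methoxy gives a 1.6-fold lower number from compound 1 to compound 3 (0.21 log units; within the scatter) and is the first step that can be read here. At this place, para to a large group, the two groups therefore cannot be told apart in this read-out, even though they differ in heavy atoms and hydrogen-bond acceptors. Nothing shown here bears on why the two groups read alike.

As far as these compounds go, whether an amine or a carboxylic acid on this aromatic carbon would also read alike stays open. So does whether this same change would give a similar step on a different core.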